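A few compounds are considered here, and "the series" means these few. Any claim that something is new, unique, unknown or untested is made for them only; others in the source may bear on it.

Compound 1 `COc1cc(NC(C)CCCNC(=O)Nc2ccc(C(F)(F)F)cc2)c2ncccc2c1`: 1900 nM
Compound 2 `COc1cc(NC(C)CCCNC(=O)Nc2cccc(C(F)(F)F)c2)c2ncccc2c1`: 3300 nM

In a functional assay on MCF7 cells (Homo sapiens) for inhibition, read by MTT assay, with a stated time of 72 h (a lower number here means a stronger inhibitor, a higher number a weaker inhibitor), compound 2 gives 3300 nM. For the measured compounds named here, the one measured step is a 1.7-fold higher number from compound 1 to compound 2 (0.24 log units; within the scatter), so the two values cannot be ordered. Compound 3 `COc1cc(NC(C)CCCNC(=O)NNC(=O)Nc2cccc(Cl)c2)c2ncccc2c1` carries ((3-chlorophenyl)carbamoyl)amino in place of 3-(trifluoromethyl)phenyl on an amide-type nitrogen. The measured step only exchanges 4-(trifluoromethyl)phenyl for 3-(trifluoromethyl)phenyl, so it gives no direction for this larger change. No step beyond the scatter is expected in this assay, with wide uncertainty. The expected step is a 1.3-fold lower number from compound 2 to compound 3 (0.12 log units; within the scatter). For compound 3 the estimate is 2500 nM, with an expected range of 400 nM to 12000 nM.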

Compound 3, half-maximal inhibitory concentration: 220 nM
Estimate against measurement, compound 3: 11-fold (1.06 log units) above; the measured number lies below the stated range.
By their numbers in this assay, from the lowest: compound 3; then compounds 1 and 2 (each within the scatter of the next).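

Placing ((3-chlorophenyl)carbamoyl)amino on the amide-type nitrogen shifts the result in this assay beyond the scatter, with a 15-fold lower number from compound 2 to compound 3 (1.18 log units; beyond the scatter) and an 8.6-fold lower number from compound 1 to compound 3 (0.94 log units; beyond the scatter) as the two steps. The exchange of 4-(trifluoromethyl)phenyl for 3-(trifluoromethyl)phenyl stayed within the scatter, so this position proves sensitive to the larger replacement. Nothing measured accounts for the shift.

Going by these compounds, whether it follows the added carbamoyl-amino unit or the chlorine remains open, since the two enter together. A 3-chlorophenyl group set directly on the amide-type nitrogen would separate them.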